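The source may report more compounds than this note shows. Statements on the series, on what has been measured and on what is new or still open speak of the compounds shown alone.

Working notes on the series. Among the compounds with values here, in a functional assay on HeLa cells (Homo sapiens) for antiproliferative activity, read by MTT assay, with a stated time of 72 h (on this read-out lower numbers stand for stronger inhibition and higher numbers for weaker inhibition), compound 2 (`O=C1COc2ccc(-c3cnc(Cl)c(NS(=O)(=O)c4ccc(F)cc4)c3)cc2N1C1CCCCC1`) gives 14300 nM, the highest of the three numbers so far. Compound 3 (`COc1ncc(-c2ccc3c(c2)N(C2CCCCC2)C(=O)CO3)cc1NS(=O)(=O)c1ccc(F)cc1`) gives 6100 nM. Compound 1 (`COc1ncc(-c2ccc3c(c2)N(c2ccc(C)cc2)C(=O)CO3)cc1NS(=O)(=O)c1ccc(F)cc1`) gives 4650 nM.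

Next is compound 4 (`CC(C)N1C(=O)COc2ccc(-c3cnc(Cl)c(NS(=O)(=O)c4ccc(F)cc4)c3)cc21`), which has isopropyl in place of cyclohexyl on an amide-type nitrogen in a ring.

Within the data shown here, the one measured change on that nitrogen, cyclohexyl in place of 4-methylphenyl, is a 1.3-fold higher number from compound 1 to compound 3 (0.12 log units; within the scatter). The other measured change, methoxy in place of chloro on an aromatic carbon, is a 2.3-fold lower number from compound 2 to compound 3 (0.37 log units; beyond the scatter). It is modest and lies elsewhere in the molecule, so it bears on the change only indirectly, as a sign of how far this series has moved so far. Among the measured compounds shown here, no isopropyl compound has been measured, and no pair with chloro differs at this nitrogen. On this evidence, no step beyond the scatter is expected in this assay, though the uncertainty is wide.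

For compound 4 the estimated value is 11000 nM, with an expected range of 5000 nM to 26000 nM. The estimate means an expected 1.3-fold lower number from compound 2 to compound 4 (0.11 log units; within the scatter).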

Compound 4, half-maximal inhibitory concentration: 5380 nM
The estimate for compound 4 lay 2.0-fold (0.31 log units) above the measured number; measured number inside the range.
By their numbers in this assay, from the lowest: compounds 1, 4 and 3 (each within the scatter of the next); then compound 2.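

With the chloro group held constant, the amide-type nitrogen now shows a step beyond the scatter in this assay: isopropyl in place of cyclohexyl gives a 2.7-fold lower number from compound 2 to compound 4 (0.42 log units; beyond the scatter). The earlier change on this nitrogen, cyclohexyl in place of 4-methylphenyl with methoxy held constant, gave a 1.3-fold higher number from compound 1 to compound 3 (0.12 log units; within the scatter), which stayed within the scatter, so the group on this nitrogen can move the number in this series. No measurement at hand gives a reason for this step.

The compounds shown leave open whether isopropyl gives a similar step when methoxy stands in place of chloro. They also leave open how an unbranched propyl chain, a methyl group or a chain ending in an amine on this nitrogen would compare with isopropyl and cyclohexyl.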